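The source may report more compounds than this note shows. Statements on the series, on what has been measured and on what is new or still open speak of the compounds shown alone.

Of the compounds shown here, two have numbers so far. In a functional assay on RCC4 cells (Homo sapiens) for antiproliferative activity, read by XTT assay, with a stated time of 48 h (on this read-out higher numbers stand for weaker inhibition and lower numbers for stronger inhibition), compound 1 (`CCCCN(Cc1cn([C@@H]2O[C@H](COC(C)=O)[C@@H](OC(C)=O)[C@H]2OC(C)=O)nn1)S(C)(=O)=O`) gives 250000 nM, and compound 2 (`COc1cccc(N(Cc2cn([C@@H]3O[C@H](COC(C)=O)[C@@H](OC(C)=O)[C@H](OC(C)=O)[C@H]3OC(C)=O)nn2)S(C)(=O)=O)c1`) gives 200000 nM. These two values lie within the scatter of each other, so compound 2 stands level with compound 1, and both sit at high numbers, which here mean weak inhibition. Compound 3 (`CC(=O)OC[C@H]1O[C@@H](n2cc(CN(c3ccc(C#N)cc3)S(C)(=O)=O)nn2)[C@H](OC(C)=O)[C@@H](OC(C)=O)[C@@H]1OC(C)=O`) has not yet been measured. It differs from compound 2 by 4-cyanophenyl in place of 3-methoxyphenyl on a sulfonamide nitrogen, with 4-cyanophenyl in place of 3-methoxyphenyl on a sulfonamide nitrogen. Among the compounds with values here, no measured pair of compounds differing in one place is available, so the data give no direct guide to this swap. In this assay no change beyond the scatter is therefore expected, and the estimated step is a 1.1-fold lower number from compound 2 to compound 3 (0.05 log units; within the scatter). For compound 3 the expected value is 180000 nM, with an estimated range of 80000 nM to 350000 nM.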

Compound 3, half-maximal inhibitory concentration: 120000 nM
Compound 3: the middle estimate sits 1.5-fold (0.18 log units) above what was measured; low and high end bracket the measured number.
By their numbers in this assay, from the lowest: compounds 3, 2 and 1 (each within the scatter of the next, the first and the last beyond it).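

The first measured pair differing in one place shows that, in this assay, 4-cyanophenyl in place of 3-methoxyphenyl on the sulfonamide nitrogen gives a 1.7-fold lower number from compound 2 to compound 3 (0.22 log units; within the scatter). This exchange of one aromatic ring substituent for another, with the heavy-atom count and hydrogen-bond acceptor count unchanged, therefore leaves the read-out within the scatter, and compound 3 remains at a high number, which here means weak inhibition. Nothing at hand explains this result or links it to any measured property of the two groups.

From the compounds shown here alone, whether an aminophenyl or carboxyphenyl group on the sulfonamide nitrogen would move the number beyond the scatter remains open. The compounds shown also leave open what free hydroxyl groups in place of the acetates on the core would do.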